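The compounds below may be only part of what the source reports. "The series", "measured", "known", "first", "only" and "open" are said of these compounds alone.

Measured so far in an ADME assay on Vero cells (Chlorocebus sabaeus) for cytotoxicity, read by MTT assay, with a stated time of 72 h; on this read-out higher numbers stand for weaker inhibition and lower numbers for stronger inhibition:
Compound 1 `O=C(O)c1cn(C2CC2)c2nc(N3CCN(C(c4ccccc4)c4ccc(Cl)cc4)CC3)c([N+](=O)[O-])cc2c1=O`: 112000 nM
Compound 2 `CC(C)(C)NC(=O)C1c2ccccc2CCN1c1nc2c(cc1[N+](=O)[O-])c(=O)c(C(=O)O)cn2C1CC1`: 124000 nM
Compound 3 `O=C(O)c1cn(-c2ccc(F)cc2)c2nc(N3CCN(C(=O)C4COc5ccccc5O4)CC3)c([N+](=O)[O-])cc2c1=O`: > 54300 nM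

In this assay, compound 2 gives 124000 nM, within the scatter of compound 1 at 112000 nM. Compound 3 gives only a limit, > 54300 nM, and not a number. Compound 4 `CC(C)(C)NC(=O)C1c2ccccc2CCN1c1nc2c(cc1[N+](=O)[O-])c(=O)c(C(=O)O)cn2-c1ccc(F)cc1` has 4-fluorophenyl in place of cyclopropyl on an aromatic nitrogen. Going by the values given here, compound 3 carries the same 4-fluorophenyl, but no measured pair isolates this change. A small shift toward a lower number is therefore expected, staying within the scatter. The estimated change is a 1.3-fold lower number from compound 2 to compound 4 (0.12 log units; within the scatter). Compound 4 is estimated at 95000 nM, with an expected range from 35000 nM to 200000 nM.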

Compound 4, half-maximal inhibitory concentration: 112000 nM
For compound 4 the middle estimate is 1.2-fold (0.07 log units) below the measured one; the measured number falls inside the stated range.
By their numbers in this assay, from the lowest: compounds 1, 4 and 2 (each within the scatter of the next).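

In this assay, the exchange of cyclopropyl for 4-fluorophenyl on the aromatic nitrogen can now be read directly, as a 1.1-fold lower number from compound 2 to compound 4 (0.04 log units; within the scatter). Going by these compounds alone, although the exchange brings in more heavy atoms and a six-membered aromatic ring, the read-out stays within the scatter, something the earlier compounds could not show. This rests on a single pair on one shared core.

On these data alone, whether an ethyl group or an aminoethyl chain on that nitrogen would read the same remains open. Compound 3, which also carries 4-fluorophenyl, gives a limit and not a number: the limit of > 54300 nM in this assay, at which 1 of the 4 values shown sits.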